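From chloro to methoxy in a small antiproliferative series

The source may report more compounds than this note shows. Statements on the series, on what has been measured and on what is new or still open speak of the compounds shown alone.

Of the compounds shown here, three have been measured so far in a functional assay on A549 cells (Homo sapiens) for antiproliferative activity, read by MTT assay, with a stated time of 72 h; on this read-out lower numbers stand for stronger inhibition and higher numbers for weaker inhibition. Compound 3 (`O=S1(=O)C=Cc2cccc(Nc3ccc(Cl)cc3)c21`) gives 1040 nM, and compound 2 (`O=S1(=O)C=Cc2cccc(Nc3ccc(OC(F)(F)F)cc3)c21`) gives 1570 nM, so these two cannot be told apart within the usual scatter. Compound 1 (`O=S1(=O)C=Cc2ccc(Nc3ccc(Cl)cc3)cc21`) has the same chloro group on a differently joined core and gives 2300 nM, a higher number than compound 3 at 1040 nM, with a gap beyond the scatter.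

Compound 4 (`COc1ccc(Nc2cccc3c2S(=O)(=O)C=C3)cc1`) keeps the core of compound 3 and has methoxy in place of chloro on an aromatic carbon, para to a large group: methoxy in place of chloro on an aromatic carbon. Among the compounds with values here, no measured compound carries methoxy, so the evidence is indirect. Within the data shown here, the only measured step that bears on this change swaps the group at the same place, chloro in place of trifluoromethoxy, and it amounts to a 1.5-fold lower number from compound 2 to compound 3 (0.18 log units; within the scatter). That single small step gives no reason to expect a large shift in this assay, although one example is a thin guide. The estimated step is a 1.3-fold higher number from compound 3 to compound 4 (0.10 log units; within the scatter), which means no change beyond the scatter is expected. Compound 4 is expected at 1300 nM, with an estimated range of 600 nM to 2800 nM.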

Compound 4, half-maximal inhibitory concentration: 2590 nM
Compound 4: middle estimate off by 2.0-fold (0.30 log units), on the low side; the range from low to high includes it.
By their numbers in this assay, from the lowest: compounds 3, 2, 1 and 4 (each within the scatter of the next, the first and the last beyond it).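

In this assay, replacing chloro with methoxy on this aromatic carbon, para to a large group, gives a 2.5-fold higher number from compound 3 to compound 4 (0.40 log units; beyond the scatter). Within the data shown here, this is the first step at this place that lies beyond the usual scatter, so the choice of group here can register in the read-out, though the effect is modest. The other new step, methyl in place of trifluoromethyl on the oxygen, gives a 1.6-fold higher number from compound 2 to compound 4 (0.22 log units; within the scatter), which lies within the scatter, so methoxy and trifluoromethoxy cannot be told apart here, just as trifluoromethoxy and chloro could not; only chloro and methoxy are separated, and no measurement available here accounts for that difference.

On these data alone, what an amine, a carboxylic acid or a longer chain such as ethoxy would do on this carbon remains open, as does the effect of plain hydrogen there. Also open, as far as these compounds go, is whether the change from chloro to methoxy would have a step of similar size on the core of compound 1, which gives 2300 nM with chloro in place.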